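Fluoro to chloro at the cyclopropylmethoxy end of the series

The compounds below may be only part of what the source reports. "The series", "measured", "known", "first", "only" and "open" are said of these compounds alone.

Measured in an ADME assay on the whole organism (Mus musculus, strain CD1) for pharmacokinetics, read by LC-MS, with a stated time of 24 h, at a dose of 1 mg/kg by the intravenous route; on this read-out lower numbers stand for slow clearance and higher numbers for fast clearance
- compound 1 `O=C(O)Cn1nc(Cc2nc3cc(Cl)c(OCC(F)F)cc3[nH]2)c2ccccc2c1=O` gives 51.7 mL/min/kg
- compound 2 `CCOc1cc2[nH]c(Cc3nn(CC(=O)O)c(=O)c4ccccc34)nc2cc1Cl` gives 23.3 mL/min/kg
- compound 3 `O=C(O)Cn1nc(Cc2nc3cc(F)c(OCC4CC4)cc3[nH]2)c2ccccc2c1=O` gives 21.7 mL/min/kg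

Compound 3 at 21.7 mL/min/kg lies within the scatter of compound 2 at 23.3 mL/min/kg and stands clear of compound 1 at 51.7 mL/min/kg on the low-clearance side. The next compound, compound 4 `O=C(O)Cn1nc(Cc2nc3cc(Cl)c(OCC4CC4)cc3[nH]2)c2ccccc2c1=O`, differs from compound 3 by chloro in place of fluoro on an aromatic carbon, with chloro in place of fluoro on an aromatic carbon, ortho to a cyclopropylmethoxy group. Within the data shown here, no measured step covers this exchange. Among the measured compounds shown here, the only step available, a 2.2-fold lower number from compound 1 to compound 2 (0.35 log units; beyond the scatter), is methyl in place of difluoromethyl on a saturated chain carbon bound to an oxygen, so it gives no size for a change at the halogen. With no evidence for a shift in either direction, the expectation in this assay starts from compound 3 at 21.7 mL/min/kg and allows no step beyond the scatter. The expected step is a 1.1-fold higher number from compound 3 to compound 4 (0.04 log units; within the scatter), and the range stays wide. For compound 4 the estimated clearance is 24 mL/min/kg, with an expected range from 11 mL/min/kg to 48 mL/min/kg.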

Compound 4, clearance in the Mus musculus assay: 18.3 mL/min/kg
The estimate for compound 4 lay 1.3-fold (0.12 log units) above the measured number; the range from low to high includes it.
By their numbers in the Mus musculus assay, from the lowest: compounds 4, 3 and 2 (each within the scatter of the next); then compound 1.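

In the Mus musculus assay this aromatic carbon, ortho to a cyclopropylmethoxy group, now has its first reading for a halogen exchange: a 1.2-fold lower number from compound 3 to compound 4 (0.07 log units; within the scatter), so clearance does not separate chloro from fluoro here. With chloro held constant, the ether end reads in two ways: a 1.3-fold lower number from compound 2 to compound 4 (0.10 log units; within the scatter) for cyclopropyl in place of methyl, and a 2.8-fold lower number from compound 1 to compound 4 (0.45 log units; beyond the scatter) for cyclopropyl in place of difluoromethyl, which leaves compound 1 alone on the fast-clearance side among the chloro compounds. In a physicochemical assay for solubility, measured as thermodynamic solubility, at pH 7.4 (a higher number here means a more soluble compound, a lower number a less soluble compound), compound 3 gives 841 ug/mL and compound 4 gives 395 ug/mL, and the same exchange does separate the pair: the measured solubility of compound 3, 841 ug/mL, and of compound 4, 395 ug/mL, a 2.1-fold lower number (0.33 log units; beyond the scatter)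

On these data alone, how a nitrile or a methyl on this aromatic carbon would read on clearance and solubility remains open. So does whether a longer ether chain in place of cyclopropylmethoxy would hold clearance at the level of compound 4.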